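A few compounds are considered here, and "the series" means these few. Any claim that something is new, unique, unknown or untested is made for them only; others in the source may bear on it.

In an ADME assay on the whole organism (Rattus norvegicus) for pharmacokinetics, using cassette dosing, at a dose of 1 mg/kg by the oral route (a lower number here means that a smaller share of the oral dose reaches the circulation, a higher number that a larger share of the oral dose reaches the circulation), compound 3 `CC(C)Oc1ccc(/N=c2\[nH]c(=O)n(C[C@H](C)C(=O)O)c(=O)n2Cc2ccc(Cl)cc2)cc1Cl` stands highest of the three measured compounds at 82.4%, clearly ahead of compound 2 `CC(C)Oc1ccc(/N=c2\[nH]c(=O)n(C[C@@H](O)CO)c(=O)n2Cc2ccc(Cl)cc2)cc1Cl` at 63% and compound 1 `Cc1ccc(Cn2c(=O)n(CC(C)(C)C(=O)O)c(=O)[nH]/c2=N\c2ccc(OC(C)C)c(Cl)c2)cc1` at 30.7%. Compound 4 `CC(C)Oc1ccc(/N=c2\[nH]c(=O)n(CC(C)(C)C(=O)O)c(=O)n2Cc2ccc(Cl)cc2)cc1Cl` departs from compound 3 in one place, on a saturated chain carbon bound to an aromatic nitrogen: 1-carboxy-1-methylethyl in place of 1-carboxyethyl on a saturated chain carbon bound to an aromatic nitrogen. Within the data shown here, one measured step touches this place, a number 19.4 percentage points higher from compound 2 to compound 3 (beyond the scatter), a modest rise beyond the scatter. Among the measured compounds shown here, that step brought in 1-carboxyethyl, so it says little about replacing it, and no measured step isolates the present change. The nearest guide is compound 1, which already carries 1-carboxy-1-methylethyl but differs from compound 4 elsewhere in the structure, and compound 1 gives 30.7%. A fall in this assay is therefore expected, probably beyond the scatter, though its size is uncertain. The estimated change is a number 22.4 percentage points lower from compound 3 to compound 4 (beyond the scatter). For compound 4 the expected value is 60%, with an estimated range from 35% to 85%.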

Compound 4, oral bioavailability: 85.3%
Compound 4: middle estimate off by 25.3 percentage points, on the low side; measured number above the stated range.
By their numbers in this assay, from the lowest: compound 1; then compound 2; then compounds 3 and 4 (each within the scatter of the next).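

In this assay, the change at this place on a saturated chain carbon bound to an aromatic nitrogen gives a number 2.9 percentage points higher from compound 3 to compound 4 (within the scatter), so 1-carboxy-1-methylethyl and 1-carboxyethyl cannot be told apart here, while a number 22.3 percentage points higher from compound 2 to compound 4 (beyond the scatter) places 1-carboxy-1-methylethyl, like 1-carboxyethyl, above 1,2-dihydroxyethyl. The low number of compound 1 therefore does not follow from 1-carboxy-1-methylethyl itself: chloro in place of methyl on an aromatic carbon accounts for a number 54.6 percentage points higher from compound 1 to compound 4 (beyond the scatter), the largest step in this set. Nothing measured here offers a reason for these steps. The compounds shown leave open how a primary amide or an amine would compare at this place. They also leave open whether the step from methyl to chloro keeps its size with 1-carboxyethyl or 1,2-dihydroxyethyl on the chain.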